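The source may hold more compounds than are shown below. What is called first, only, known or untested is meant among the compounds shown, and "the series" means these compounds.

Compound 1 `NC[C@H]1O[C@H](CO)[C@@H](O)[C@H](O)[C@H]1O` is a sugar-like ring that carries an aminomethyl group. In an assay on isolated protein (Sus scrofa) for inhibition of glycogen phosphorylase, brain form (Homo sapiens) (a lower number here means a stronger inhibitor, a higher number a weaker inhibitor), compound 1 gives 31600000 nM, the highest number of the three measured compounds, so it is the weakest binder shown. Its nearest neighbour is compound 2 `NC[C@@H]1O[C@H](CO)[C@@H](O)[C@H](O)[C@H]1O`, which gives 15800000 nM; the step of a 2.0-fold lower number from compound 1 to compound 2 (0.30 log units; within the scatter) rests only on a change in configuration (the fact that compounds 1 and 2 differ only in the configuration as drawn). Compound 3 `O=C(CS[C@H]1O[C@H](CO)[C@@H](O)[C@H](O)[C@H]1O)Nc1ccccc1`, which carries an anilide-bearing thioether in place of the aminomethyl group, gives 3980000 nM, the lowest number of the three, though all three remain very weak.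

Compound 4 `O=C(O)[C@H]1O[C@H](CO)[C@@H](O)[C@H](O)[C@H]1O` differs from compound 1 by carboxy in place of aminomethyl on a saturated ring carbon. For the measured compounds named here, the only measured step, the configurational change from compound 1 to compound 2, stayed within the scatter and does not speak to swapping one small polar group for another. With no guide beyond that, the expectation for compound 4 is a number close to that of compound 1, with the step of a 1.3-fold lower number from compound 1 to compound 4 (0.10 log units; within the scatter) expected to fall within the scatter. Compound 4 is therefore estimated at 25000000 nM in this assay, expected to lie between 6000000 nM and 100000000 nM.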

Compound 4, inhibition constant: 15800000 nM
For compound 4 the middle estimate is 1.6-fold (0.20 log units) above the measured one; the range from low to high includes it.
By their numbers in this assay, from the lowest: compound 3; then compounds 2, 4 and 1 (each within the scatter of the next).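

In this assay, the step of a 2.0-fold lower number from compound 1 to compound 4 (0.30 log units; within the scatter) shows that, on this saturated ring carbon next to the ring oxygen, carboxy can stand in place of aminomethyl without a change beyond the scatter. The earlier step within the scatter involved configuration alone, whereas this one exchanges the group itself and still leaves the number in the same very weak range. Nothing measured here gives a reason for this result.

From the compounds shown here alone, it remains open whether a larger group at this position, such as a methyl ester, an amide or a longer chain ending in an amine or a carboxylic acid, would shift the number beyond the scatter. Going by these compounds, it is also open whether carboxy would give a similar number with the opposite drawn configuration at this ring carbon.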